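Removing One Methoxy Group on a Second Core

This account rests on a few compounds, and the source may have more. Where it says the series, first, only, none or still open, it means among the compounds named here.

Compound 1, `COc1cc(-c2cc(/C=C/C(=O)c3ccc(N)cc3)[nH]n2)cc(OC)c1OC`, and compound 2, `COc1ccc(-c2cc(/C=C/C(=O)c3ccc(N)cc3)[nH]n2)cc1OC`, were both tested in a functional assay on RPMI-8226 cells (Homo sapiens) for cytotoxicity, read by sulforhodamine B assay, with a stated time of 48 h, tested at 1 uM; on this read-out higher numbers stand for a weaker effect at the one concentration tested and lower numbers for a stronger effect. Here compound 1 gives 28%, while compound 2 gives 59%. The structural change between them is hydrogen in place of methoxy on an aromatic carbon, and the step it made was a number 31 percentage points higher from compound 1 to compound 2 (beyond the scatter). Compound 3, `COc1cc(C(=O)/C=C/c2cc(-c3cc(OC)c(OC)c(OC)c3)n[nH]2)cc(OC)c1OC`, is built on a different core; the difference between the two cores is not broken down here. In this assay compound 3 gives 17%, the lowest of the three numbers. Compound 4, `COc1ccc(-c2cc(/C=C/C(=O)c3cc(OC)c(OC)c(OC)c3)[nH]n2)cc1OC`, differs from compound 3 by hydrogen in place of methoxy on an aromatic carbon, and since the surroundings of the place read identically, this is the same change as that between compound 1 and compound 2. Resting on that single earlier step, the step expected is a number 25 percentage points higher from compound 3 to compound 4 (beyond the scatter). Compound 4 is therefore estimated at about 42%, most likely between 25% and 60%.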

Compound 4, a percentage reported as activity, at one concentration (the size of the read-out at that concentration, not a potency): 11%
Estimate against measurement, compound 4: 31 percentage points above; the whole stated range lies above it.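

In this assay, putting hydrogen in place of methoxy gave a number 6 percentage points lower from compound 3 to compound 4 (within the scatter), so on this core the change made no step beyond the usual scatter. The same change therefore did not behave alike on the two cores: the same change on two cores in this assay, a number 31 percentage points higher (beyond the scatter) from compound 1 to compound 2 and a number 6 percentage points lower (within the scatter) from compound 3 to compound 4, 37 percentage points apart, beyond the scatter of two such steps. This shows that a step seen on one core cannot simply be carried to another in this series, but two pairs of compounds do not show which part of the cores is responsible, nor how potency would differ, since only one concentration was tested.

The compounds shown leave open what a hydroxyl group or a fluorine atom would do at this place. They also leave open which of the two steps a third core would follow.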